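The source may hold more compounds than are shown below. What is called first, only, known or untested is meant among the compounds shown, and "the series" means these compounds.

Working notes on the series.

Compound 1 `O=C(CO[C@@H]1C[C@@H](CNc2ccccn2)N(C(=O)OCc2ccccc2)C1)NC[C@H](NC(=O)c1ccccc1)C(=O)O` is taken as the reference point. In an assay on a protein complex for inhibition of integrin alpha-5/beta-1 (Homo sapiens), read by ELISA (on this read-out lower numbers stand for stronger inhibition and higher numbers for weaker inhibition), compound 1 gives 155 nM, which is the second highest of the three numbers available. Compound 3 `Cc1cc(C)c(S(=O)(=O)N[C@@H](CNC(=O)CO[C@@H]2C[C@@H](CNc3ccccn3)N(CCCc3ccccc3)C2)C(=O)O)c(C)c1` gives 670 nM, the nearest measured value to compound 1 and still beyond the scatter from it. Compound 2 `COc1ccnc(NC[C@@H]2C[C@@H](OCC(=O)NC[C@H](NC(=O)c3c(C)cc(C)cc3C)C(=O)O)CN2C(=O)CC(C)(C)C)c1` gives 0.55 nM, the furthest from compound 1 and also beyond the scatter. Going by the values given here, compound 2 and compound 3 each differ from compound 1 in more than one place, so no pair of measured compounds shows a single change on its own, and nothing in the measured set isolates the effect of any one group.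

Compound 4 `Cc1cc(C)c(C(=O)N[C@@H](CNC(=O)CO[C@@H]2C[C@@H](CNc3ccccn3)N(C(=O)OCc3ccccc3)C2)C(=O)O)c(C)c1` is not yet measured. It differs from compound 1 in one place: 2,4,6-trimethylphenyl in place of phenyl on a carbonyl carbon. The same 2,4,6-trimethylphenyl on a carbonyl carbon is present in compound 2, which gives 0.55 nM; the other changes in compound 2 make that value an uncertain guide. The expected step of a 3.1-fold lower number from compound 1 to compound 4 (0.49 log units; beyond the scatter) is modest, in the direction of stronger inhibition, and may not exceed the scatter. The estimate for compound 4 is 50 nM, with a range from 15 nM to 150 nM.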

Compound 4, half-maximal inhibitory concentration: 3.5 nM
Beside the measured number, compound 4's estimate is 14-fold (1.15 log units) above it; the whole stated range lies above it.
By their numbers in this assay, from the lowest: compound 2; then compound 4; then compound 1; then compound 3.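

In this assay, 2,4,6-trimethylphenyl in place of phenyl on a carbonyl carbon gives a 44-fold lower number from compound 1 to compound 4 (1.65 log units; beyond the scatter), the first effect in the series that can be read from a single change, and it shows that this position alone can move the number by a large step with the rest of compound 1 held fixed. The heavy atoms added by the change are all carbon, while the aromatic ring type, the counts of hydrogen-bond donors and acceptors, and the net charge are the same on both sides, so the large step comes without any difference in those counted features. Nothing available here explains the size of the step or ties it to a measured property of either group.

The compounds shown leave open whether all three methyl groups are needed, as a single step to 4-methylphenyl or 2,6-dimethylphenyl on the same carbonyl carbon would show, and whether chloro in place of methyl would serve equally. They also leave open whether a step of this size would recur on a core other than that of compound 1.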